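Matched changes in a mouse melanoma cell growth assay

This account rests on a few compounds, and the source may have more. Where it says the series, first, only, none or still open, it means among the compounds named here.

Measured so far, in a functional assay on B16-F10 cells (Mus musculus) for inhibition, read by MTT assay, with a stated time of 72 h; a higher number here means a weaker inhibitor, a lower number a stronger inhibitor:
Compound 1 `Cc1ccc(Nc2nc(SCc3cn(Cc4ccc(Cl)cc4)nn3)nc(-c3ccccc3)c2C#N)cc1` gives 15100 nM.
Compound 2 `N#Cc1c(Nc2ccccc2F)nc(SCc2cn(Cc3ccc(Cl)cc3)nn2)nc1-c1ccccc1` gives only a limit of the assay, > 64000 nM.
Compound 3 `Cc1ccc(Cn2cc(CSc3nc(Nc4ccccc4F)c(C#N)c(-c4ccccc4)n3)nn2)cc1` gives 16000 nM.

Compound 2 and compound 3 share a core that differs in one place, (methyl in place of chloro on an aromatic carbon), and that step reads an at least 4.0-fold lower number from compound 2 to compound 3 (0.60 log units; beyond the scatter). Compound 1 arises from compound 2 by a different change, (4-methylphenyl in place of 2-fluorophenyl on a nitrogen on an aromatic ring), with the step of an at least 4.2-fold lower number from compound 2 to compound 1 (0.62 log units; beyond the scatter). Both steps start from a value that is a limit, (the limit of > 64000 nM in this assay, at which 1 of the 3 values shown sits), so only their lower bound is known.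

Compound 4 `Cc1ccc(Cn2cc(CSc3nc(Nc4ccc(C)cc4)c(C#N)c(-c4ccccc4)n3)nn2)cc1` is not yet measured. It arises from compound 3 by 4-methylphenyl in place of 2-fluorophenyl on a nitrogen on an aromatic ring, the same change as that from compound 2 to compound 1, made on the same kind of place. On that earlier step, an at least 4.2-fold lower number from compound 2 to compound 1 (0.62 log units; beyond the scatter), compound 4 is expected to show a step of a 2.7-fold lower number from compound 3 to compound 4 (0.43 log units; beyond the scatter) in this assay, though the limit behind the earlier step leaves its true size open. The estimate for compound 4 is 6000 nM, between 2500 nM and 15000 nM.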

Compound 4, half-maximal inhibitory concentration: 8160 nM
Estimate against measurement, compound 4: 1.4-fold (0.13 log units) below; measured number inside the range.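

In this assay, putting 4-methylphenyl in place of 2-fluorophenyl on the nitrogen gives a 2.0-fold lower number from compound 3 to compound 4 (0.29 log units; within the scatter), and putting methyl in place of chloro on an aromatic carbon gives a 1.9-fold lower number from compound 1 to compound 4 (0.27 log units; within the scatter), so on these cores neither change stands out from the ordinary spread of repeat measurements. For the first change, the data do not show whether the effect carries over at the same size or shrinks on the second core: the same change on two cores in this assay, an at least 4.2-fold lower number (0.62 log units; beyond the scatter) from compound 2 to compound 1 and a 2.0-fold lower number (0.29 log units; within the scatter) from compound 3 to compound 4; the limit leaves it open whether they differ. The second change is just as unsettled: the same change on two cores in this assay, an at least 4.0-fold lower number (0.60 log units; beyond the scatter) from compound 2 to compound 3 and a 1.9-fold lower number (0.27 log units; within the scatter) from compound 1 to compound 4; the limit leaves it open whether they differ.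

Going by these compounds, the true size of both steps starting from compound 2 remains unknown, so a firm rule for moving either change between cores cannot be drawn from these four compounds. On these data alone, it also remains open what a plain phenyl or a 4-methoxyphenyl on that nitrogen would give, or how a bromo or a methoxy in place of the methyl on the other aromatic ring would compare.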